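This account rests on a few compounds, and the source may have more. Where it says the series, first, only, none or still open, it means among the compounds named here.

Measured compounds:
compound 1, `FC(F)(F)c1cccc(Nc2nc3nonc3nc2Nc2cccc(C(F)(F)F)c2)c1`: 700 nM
compound 2, `Fc1cccc(Nc2nc3nonc3nc2Nc2ccccc2F)c1`: 190 nM

Both were run in an assay on mitochondria from L6 cells (Rattus norvegicus) for activation, with a stated time of 90 min; on this read-out higher numbers stand for an effect only at larger amounts of compound and lower numbers for an effect already at smaller amounts. Compound 1 gives 700 nM in this assay, while compound 2 gives 190 nM, the lower of the two numbers; the gap to compound 1 lies beyond the usual scatter of repeated measurements, so compound 2 stands as the more active of the pair on this read-out.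

Compound 3, `COc1ccc(Nc2nc3nonc3nc2Nc2ccccc2F)cc1`, is not yet measured. Relative to compound 2 it differs in one place: 4-methoxyphenyl in place of 3-fluorophenyl on a nitrogen on an aromatic ring. Within the data shown here, no pair of measured compounds shows this change, so its effect is unknown; the change is expected to give a step of only modest size, if any, with no direction that can be read from the two measured compounds. The estimated step of a 1.6-fold higher number from compound 2 to compound 3 (0.20 log units; within the scatter) is a slight weakening that may fall within the scatter. For compound 3 the expected value in this assay is 300 nM, with a range from 100 nM to 900 nM.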

Compound 3, half-maximal effective concentration: 1600 nM
Estimate against measurement, compound 3: 5.3-fold (0.73 log units) below; the whole stated range lies below it.
By their numbers in this assay, from the lowest: compound 2; then compound 1; then compound 3.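

In this assay, 4-methoxyphenyl in place of 3-fluorophenyl on this nitrogen gives an 8.4-fold higher number from compound 2 to compound 3 (0.93 log units; beyond the scatter), so the read-out depends on which substituted phenyl sits at this position. Among these compounds, this is the first step that isolates one place: the rest of the structure is the same in both compounds, so the whole step belongs to this exchange. Nothing at hand accounts for the size or direction of this step.

On these data alone, the exchange alters both the substituent and its ring position, so it remains open whether the methoxy group itself or its location carries the step. The compounds shown also leave open how a 3-methoxyphenyl, a 4-fluorophenyl or a phenyl bearing an amine or a carboxylic acid would read out on this nitrogen.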